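From 3,4-dimethoxyphenyl to phenyl on a stable compound

The source may report more compounds than this note shows. Statements on the series, on what has been measured and on what is new or still open speak of the compounds shown alone.

In an ADME assay on microsomes from liver (Mus musculus) for metabolic stability, read by LC-MS, with NADPH named in the record, with a stated time of 60 min, tested at 1 uM, in the absence of a further agent (a higher number here means that more of the compound is left, a lower number that less of the compound is left), compound 1 `COc1ccc(-c2c(C)nc3c(N4CC[C@@H](NC(C)=O)C4)cc(C)nn23)cc1OC` gives > 95% as its reading, a limit of the assay and not an exact number. Compound 2 `COc1ccc(-c2scc3c(N4CC[C@@H](NC(C)=O)C4)nc(C)nc23)cc1OC` also reports only a limit, with > 95% as its reading. Compound 1 and compound 2 therefore share one standing (the limit of > 95% in this assay, at which 2 of the 2 values shown sit), and compound 1 offers no exact number to start from.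

Compound 3 `CC(=O)N[C@@H]1CCN(c2cc(C)nn3c(-c4ccccc4)c(C)nc23)C1` has not yet been measured. It carries phenyl in place of 3,4-dimethoxyphenyl on an aromatic carbon, while the rest of compound 1 stays unchanged. Going by the values given here, no measured pair shows what such a swap does, so the expectation rests only on compound 1 with its > 95% reading, which is a limit. The expected step of a number at least 2 percentage points lower from compound 1 to compound 3 (that floor lies within the scatter) is none beyond the usual scatter, with a slight drop as the only direction worth allowing for. Compound 3 is estimated at 93% in this assay with an expected range from 80% to 100% as its likely readings.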

Compound 3, percent of the compound remaining: > 95%
Compound 3 gave a limit, no number (the forecaster's own chance of this, stated with the estimate: 45%); middle value at least 2 percentage points from the limit.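

In this assay compound 3 gives > 95%, a limit of the assay and not a number. No step from compound 1 to compound 3 can be read, because both compounds stop at a limit: the limit of > 95% in this assay, at which 3 of the 3 values shown sit.

The compounds shown leave open whether phenyl in place of 3,4-dimethoxyphenyl changes how much compound remains at all.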